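The compounds below may be only part of what the source reports. "The series", "measured", "known", "first", "only" and "open" are said of these compounds alone.

Among the measured compounds shown here, in a functional assay on HCT-116 cells (Homo sapiens) for inhibition, read by MTT assay, with a stated time of 48 h (a higher number here means a weaker inhibitor, a lower number a stronger inhibitor), compound 1 (`COc1ccc(CNc2cc(OC)c(OC)c(OC)c2)cc1[N+](=O)[O-]`) gives 18200 nM and holds the higher of the two numbers so far. Compound 2 (`COc1ccc(CN(C(=O)C(C)Br)c2cc(OC)c(OC)c(OC)c2)cc1O`) gives 140 nM and lies beyond the scatter from compound 1. Compound 3 (`COc1ccc(CNc2cc(OC)c(OC)c(OC)c2)cc1C`) differs from compound 1 by methyl in place of nitro on an aromatic carbon. For the measured compounds named here, no measured pair shows this change on its own. In this assay the expected move is small and within the scatter, with the estimated 1.2-fold lower number from compound 1 to compound 3 (0.08 log units; within the scatter) pointing slightly toward a lower number. For compound 3 the estimate is 15000 nM with 4000 nM to 50000 nM as its expected range.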

Compound 3, half-maximal inhibitory concentration: 60900 nM
Beside the measured number, compound 3's estimate is 4.1-fold (0.61 log units) below it; measured number outside the range, above it.
By their numbers in this assay, from the lowest: compound 2; then compound 1; then compound 3.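

In this assay, methyl in place of nitro on this aromatic carbon, ortho to a methoxy group, gives a 3.3-fold higher number from compound 1 to compound 3 (0.52 log units; beyond the scatter). Among the compounds shown here, this is the first sign that the position responds to what it carries, with the nitro compound the stronger of this pair. Nothing available explains the step. The compounds shown leave open whether an amine, a nitrile or a carboxylic acid on the same carbon would fall nearer compound 1 or compound 3, and whether this step would hold on another core.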